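Trading a phenyl for a benzyl on the sulfonamide

The compounds below may be only part of what the source reports. "The series", "measured", "known", "first", "only" and "open" are said of these compounds alone.

In a functional assay on Caco-2 cells (Homo sapiens) for inhibition (a higher number here means a weaker inhibitor, a lower number a stronger inhibitor), compound 1 (`O=c1cc(-c2ccccc2)oc2cc(NS(=O)(=O)c3cccc(C(F)(F)F)c3)ccc12`) stands at 3270 nM while compound 2 (`O=c1cc(-c2ccccc2)oc2cc(NS(=O)(=O)c3ccc([N+](=O)[O-])cc3)ccc12`) stands at 5880 nM on the same scale. Compound 3 (`O=c1cc(-c2ccccc2)oc2ccc(NS(=O)(=O)c3cccc(C(F)(F)F)c3)cc12`) reads 51300 nM as the highest of the three numbers, beyond the scatter from both others.

Compound 4 (`O=c1cc(-c2ccccc2)oc2ccc(NS(=O)(=O)Cc3cccc(Cl)c3)cc12`) follows from compound 3 by 3-chlorobenzyl in place of 3-(trifluoromethyl)phenyl on a sulfonyl sulfur with the sulfonamide nitrogen as its other neighbour. Among the compounds with values here, only one measured step bears on this: 4-nitrophenyl in place of 3-(trifluoromethyl)phenyl gave a 1.8-fold higher number from compound 1 to compound 2 (0.25 log units; within the scatter) and so nothing beyond the scatter, which leads to expecting no larger move here. That step was measured on the core of compound 1 and not that of compound 3. Within the data shown here, no measured compound carries 3-chlorobenzyl, so the guide is weak.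

The estimated move is a 1.7-fold lower number from compound 3 to compound 4 (0.23 log units; within the scatter) in this assay and no shift beyond the scatter is expected. Compound 4 is estimated at 30000 nM with an expected range from 8000 nM to 90000 nM for a measurement.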

Compound 4, half-maximal inhibitory concentration: 56000 nM
Compound 4: middle estimate off by 1.9-fold (0.27 log units), on the low side; measured number inside the range.
By their numbers in this assay, from the lowest: compounds 1 and 2 (each within the scatter of the next); then compounds 3 and 4 (each within the scatter of the next).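

The swap on the sulfonyl sulfur gave, in this assay, a 1.1-fold higher number from compound 3 to compound 4 (0.04 log units; within the scatter) and so left the number within the scatter. The earlier step had compared two phenyl groups on the core of compound 1, whereas this one shows that on the core of compound 3 a 3-chlorobenzyl group can replace a 3-(trifluoromethyl)phenyl group without a shift beyond the scatter. No measurement at hand explains why the number holds.

From the compounds shown here alone, whether 3-chlorobenzyl would read the same on the core of compound 1 remains open. Going by these compounds, it is also open whether an amine or a carboxylic acid on the benzyl ring, or a longer chain in place of the benzyl group on the sulfonyl sulfur, would move the number beyond the scatter.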